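The source may hold more compounds than are shown below. What is called first, only, known or untested is meant among the compounds shown, and "the series" means these compounds.

Measured compounds:
- compound 1, `CC1(NC2=NS(=O)(=O)c3sc(Cl)cc3N2)CC1`: 600 nM
- compound 2, `COc1ccc(Oc2ccc([N+](=O)[O-])cc2C(=O)Nc2ccc(C(C)=O)cc2)cc1`: 8100 nM
- compound 3, `COc1ccc(NC(=O)c2ccccc2Oc2ccccc2)cc1`: "no significant activity" (no number reported)

In a functional assay (Homo sapiens) for inhibition, using a membrane potential dye, in the presence of a further agent that is not named here (on this read-out higher numbers stand for weaker inhibition and lower numbers for stronger inhibition), compound 1 gives 600 nM. In this assay compound 2 gives 8100 nM, the highest of the two numbers recorded, and its gap to compound 1 lies beyond the scatter of repeated runs. In this assay compound 3 gives "no significant activity" (no number reported), so no number stands against it; it differs from compound 2 in more than one place, and nothing is computed between the two.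

Compound 4, `COc1ccc(NC(=O)c2cc([N+](=O)[O-])ccc2Oc2ccc(OC)cc2)cc1`, is not yet measured. It differs from compound 2 as follows: methoxy in place of acetyl on an aromatic carbon. For the measured compounds named here, no pair of measured compounds shows this change, so its size is unknown here. Compound 3, which carries the same amine-side group as compound 4 but lacks the other substituents of compound 2, gave no measurable number, which weighs toward a weaker result. In this assay compound 4 is expected to give 15000 nM, within 5000 nM to 60000 nM. The step of a 1.9-fold higher number from compound 2 to compound 4 (0.27 log units; within the scatter) is thus estimated as a modest rise, possibly not beyond the scatter.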

Compound 4, half-maximal inhibitory concentration: 3400 nM
Estimate against measurement, compound 4: 4.4-fold (0.64 log units) above; measured number below the stated range.
By their numbers in this assay, from the lowest: compound 1; then compound 4; then compound 2.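

In this assay, for the compounds shown here, methoxy in place of acetyl on the aromatic carbon para to a large group gives a 2.4-fold lower number from compound 2 to compound 4 (0.38 log units; beyond the scatter), the only single-place change that can be read so far. The acetyl is therefore not required for a measurable number at this position, and the 4-methoxyphenyl group does modestly better than the 4-acetylphenyl group. No data at hand explain this step.

On these data alone, a single step at one position gives no trend, so it remains open whether an amine or a carboxylic acid on the same carbon would shift the number further in either direction. Also open, as far as these compounds go, is whether the same change holds in a compound without the nitro group, and how this family relates to the core of compound 1.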